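A Trifluoromethyl Swap Tested at a Second Position

A few compounds are considered here, and "the series" means these few. Any claim that something is new, unique, unknown or untested is made for them only; others in the source may bear on it.

Measured compounds and their values in an assay on mitochondria from L6 cells (Rattus norvegicus) for activation, with a stated time of 90 min; on this read-out lower numbers stand for an effect already at smaller amounts and higher numbers for an effect only at larger amounts of compound:
compound 1, `Oc1nc2nonc2nc1Nc1ccccc1F`, gives 12500 nM
compound 2, `Oc1nc2nonc2nc1Nc1ccc(F)cc1`, gives 38600 nM
compound 3, `Oc1nc2nonc2nc1Nc1ccccc1C(F)(F)F`, gives 10600 nM

Of the compounds shown here, three sharing one core have been measured. Compound 2 gives the highest number of the three, and its nearest neighbour, compound 1, lies beyond the usual scatter from it. Compound 1 and compound 2 are built from the same atoms joined differently; the difference between the two cores is not broken down here. From compound 1 to compound 3 the change is trifluoromethyl in place of fluoro on an aromatic carbon. This gave a 1.2-fold lower number from compound 1 to compound 3 (0.07 log units; within the scatter), so those two numbers cannot be told apart.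

The unmeasured compound 4, `Oc1nc2nonc2nc1Nc1ccc(C(F)(F)F)cc1`, arises from compound 2 by trifluoromethyl in place of fluoro on an aromatic carbon. This is the same kind of change as the earlier one, but not the same: in the earlier pair the group sits ortho to a large group, here it sits para to a large group. Within the data shown here, only one earlier instance exists, and it was within the scatter.

Among the measured compounds shown here, compound 4 is expected to show a 1.2-fold lower number from compound 2 to compound 4 (0.08 log units; within the scatter), an expectation that rests on a 1.2-fold lower number from compound 1 to compound 3 (0.07 log units; within the scatter) as the sole precedent. Compound 4 is therefore estimated at 32000 nM in this assay. Its expected range runs from 12000 nM to 85000 nM. For the measured compounds named here, the range is wide because a 1.2-fold lower number from compound 1 to compound 3 (0.07 log units; within the scatter) is the only precedent and was within the scatter, so it carries little weight.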

Compound 4, half-maximal effective concentration: 10400 nM
The estimate for compound 4 lay 3.1-fold (0.49 log units) above the measured number; measured number below the stated range.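

In this assay, putting trifluoromethyl in place of fluoro, para to a large group, gave a 3.7-fold lower number from compound 2 to compound 4 (0.57 log units; beyond the scatter), a step that stands clear of the usual scatter between repeated measurements. The same swap therefore did not carry over at the same size from one core to the other, so a step seen on one core is a poor guide to the step on the next: the same change on two cores in this assay, a 1.2-fold lower number (0.07 log units; within the scatter) from compound 1 to compound 3 and a 3.7-fold lower number (0.57 log units; beyond the scatter) from compound 2 to compound 4, 3.1-fold (0.50 log units) apart, beyond the scatter of two such steps. Among these compounds, with only one pair on each core, this shows that the swap can behave differently, but it does not show why the two steps differ, nor which size of step to expect on any further core.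

The compounds shown carry only fluoro or trifluoromethyl on the aromatic ring, so it remains open how a methyl group, a methoxy group, a nitrile or an amine would behave there. Going by these compounds, it also remains open whether the difference between the two steps would hold on any other core, or in any read-out other than this one.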